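Changing the amide substituent from compound 2 to compound 4

The compounds below may be only part of what the source reports. "The series", "measured", "known", "first", "only" and "open" are said of these compounds alone.

Compound 1 `NNC(=O)c1c(NC(=O)NS(=O)(=O)c2ccccc2)sc2c1CCCCC2`: 10500 nM
Compound 2 `CN1CCN(C(=O)c2c(NC(=O)NS(=O)(=O)c3ccccc3)sc3c2CCCCC3)CC1`: 22300 nM
Compound 3 `O=C(Nc1sc2c(c1C(=O)NNc1ccc(Br)cc1)CCCCC2)NS(=O)(=O)c1ccccc1`: 11500 nM

In a functional assay on NSCLC cells (Homo sapiens) for inhibition, with a stated time of 48 h (on this read-out higher numbers stand for weaker inhibition of growth and lower numbers for stronger inhibition of growth), compound 2 gives the highest number of the three, although compound 3 lies within the scatter of it and only compound 1 sits beyond. Compound 4 `CCCCNC(=O)c1c(NC(=O)NS(=O)(=O)c2ccccc2)sc2c1CCCCC2` differs from compound 2 by one change at the carbonyl carbon (butylamino in place of 4-methylpiperazin-1-yl on a carbonyl carbon). Among the compounds with values here, two measured steps touch the same carbonyl carbon: a 2.1-fold higher number from compound 1 to compound 2 (0.33 log units; beyond the scatter) and a 1.9-fold lower number from compound 2 to compound 3 (0.29 log units; within the scatter). Both point toward the number falling slightly when the 4-methylpiperazin-1-yl group is exchanged for a group carrying an amine hydrogen, as in compound 1 and compound 3. For compound 4, a modest step downward is therefore expected, a 2.0-fold lower number from compound 2 to compound 4 (0.31 log units; beyond the scatter). Compound 4 is estimated at 11000 nM, with a range from 5000 nM to 25000 nM.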

Compound 4, concentration for 50% growth inhibition: 30300 nM
Compound 4: middle estimate off by 2.8-fold (0.44 log units), on the low side; the whole stated range lies below it.
By their numbers in this assay, from the lowest: compounds 1, 3, 2 and 4 (each within the scatter of the next, the first and the last beyond it).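

In this assay, butylamino on the carbonyl carbon, despite its amide hydrogen, does not separate from 4-methylpiperazin-1-yl: a 1.4-fold higher number from compound 2 to compound 4 (0.13 log units; within the scatter). Butyl on the amide-type nitrogen does separate from the two groups it replaces there, with a 2.9-fold higher number from compound 1 to compound 4 (0.46 log units; beyond the scatter) and a 2.6-fold higher number from compound 3 to compound 4 (0.42 log units; beyond the scatter), so the amide hydrogen alone does not accompany the lower numbers of compound 1 and compound 3, which both carry a further nitrogen at that place. No evidence is available to explain this difference. As far as these compounds go, it remains open whether that nitrogen or the butyl chain sets the gap, which a shorter chain such as ethyl or a benzyl group on the same nitrogen could help separate.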